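Swapping cyclohexylmethoxy for (4-fluorophenyl)sulfanyl on the shared core

The compounds below may be only part of what the source reports. "The series", "measured", "known", "first", "only" and "open" are said of these compounds alone.

- compound 1 (`C=CCOc1ncnc2[nH]cnc12`) gives 44700 nM
- compound 2 (`Fc1ccc(Sc2ncnc3[nH]cnc23)cc1`) gives 31600 nM
- compound 3 (`c1ccc2c(c1)COC(n1cnc3c(OCC4CCCCC4)ncnc31)CO2`) gives 11600 nM

All three values come from a functional assay on MCF7 cells (Homo sapiens) for antiproliferative activity, read by sulforhodamine B assay, with a stated time of 3 days (a higher number here means a weaker inhibitor, a lower number a stronger inhibitor), and compound 3 holds the lowest of the three numbers, beyond the scatter from both others. Compound 4 (`Fc1ccc(Sc2ncnc3c2ncn3C2COc3ccccc3CO2)cc1`) differs from compound 3 in one place, on an aromatic carbon: (4-fluorophenyl)sulfanyl in place of cyclohexylmethoxy ((4-fluorophenyl)sulfanyl in place of cyclohexylmethoxy on an aromatic carbon). Within the data shown here, no step between measured compounds gauges this change. Compound 2 also carries (4-fluorophenyl)sulfanyl and stands higher (31600 nM), but it does not isolate the change. No step beyond the scatter is expected, so the estimate is a 1.3-fold lower number from compound 3 to compound 4 (0.11 log units; within the scatter) in this assay and its direction is uncertain. For compound 4 the estimated value is 9000 nM (expected range 2500 nM to 30000 nM).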

Compound 4, half-maximal inhibitory concentration: 11200 nM
Compound 4: middle estimate off by 1.2-fold (0.09 log units), on the low side; the measured number falls inside the stated range.
By their numbers in this assay, from the lowest: compounds 4 and 3 (each within the scatter of the next); then compounds 2 and 1 (each within the scatter of the next).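

In this assay, the first step read at this position, on an aromatic carbon next to the ring nitrogen, is a 1.0-fold lower number from compound 3 to compound 4 (0.02 log units; within the scatter), within the scatter. An aromatic ring carried through sulfur and a non-aromatic ring carried through oxygen are therefore not told apart at this position in this pair. Nothing available on these compounds accounts for this result.

From the compounds shown here alone, whether a different kind of group here, such as an amine or a longer alkyl chain, would shift the number remains open. The contribution of the other substituent shared by compound 3 and compound 4 also remains unisolated.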